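From 4-phenylphenyl to 2-methoxyphenyl: an expected cytotoxicity read-out

The source may report more compounds than this note shows. Statements on the series, on what has been measured and on what is new or still open speak of the compounds shown alone.

Compound 1 `O=c1cc(-c2ccccc2)oc2cc(OCCCCCCCCN3CCCC3)ccc12`: 11.3%
Compound 2 `O=c1cc(-c2ccc(-c3ccccc3)cc2)oc2cc(OCCCCCCCCN3CCCC3)ccc12`: 13.9%

In an ADME assay on HepG2 cells (Homo sapiens) for cytotoxicity, read by MTT assay, with a stated time of 48 h, tested at 1 uM (on this read-out lower numbers stand for a weaker effect and higher numbers for a stronger effect at the one concentration tested), compound 1 gives 11.3% and compound 2 gives 13.9%. Within the data shown here, the one measured step, a number 2.6 percentage points higher from compound 1 to compound 2 (within the scatter), stays within the scatter, so compound 2 stands level with compound 1 and both show a weak effect. Compound 3 `COc1ccccc1-c1cc(=O)c2ccc(OCCCCCCCCN3CCCC3)cc2o1` differs from compound 2 by 2-methoxyphenyl in place of 4-phenylphenyl on an aromatic carbon. Among the measured compounds shown here, no measured step involves 2-methoxyphenyl, and the only step known, which added phenyl, was within the scatter. The step of a number 1.9 percentage points lower from compound 2 to compound 3 (within the scatter) is therefore expected to stay within the scatter. Compound 3 is estimated at 12%, between 2% and 25%.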

Compound 3, a percentage reported as inhibition, at one concentration (the size of the read-out at that concentration, not a potency): 5.9%
For compound 3 the middle estimate is 6.1 percentage points above the measured one; low and high end bracket the measured number.
By their numbers in this assay, from the lowest: compounds 3, 1 and 2 (each within the scatter of the next).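

In this assay, 2-methoxyphenyl in place of 4-phenylphenyl gives a number 8 percentage points lower from compound 2 to compound 3 (within the scatter) and methoxy in place of hydrogen gives a number 5.4 percentage points lower from compound 1 to compound 3 (within the scatter) and both steps lie within the scatter. This position on the shared core has now carried three aromatic groups, one of them with an oxygen, and no two of their read-outs are separated beyond the scatter. The size of the group and the added methoxy therefore show no clear effect on this read-out. As far as these compounds go, what an amine or a carboxylic acid on the aromatic group here would do remains open, and no measured evidence bears on this result.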